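Lengthening a Side Chain on the Acid Analogue

The source may hold more compounds than are shown below. What is called first, only, known or untested is meant among the compounds shown, and "the series" means these compounds.

Of the compounds shown here, three built on one shared core have been measured in a functional assay on Hep 3B2 cells (Homo sapiens) for antiproliferative activity, read by MTT assay, with a stated time of 24 h, tested at 33.33 ug/mL; on this read-out higher numbers stand for a stronger effect at the one concentration tested and lower numbers for a weaker effect. Compound 1 `Cc1ccc2nc(C(=O)Nc3c(F)cc(-c4cccc(F)c4)cc3F)c(C)c(O)c2c1` gives 37.3%. Compound 2 `CCc1ccc2nc(C(=O)Nc3c(F)cc(-c4cccc(F)c4)cc3F)c(C)c(O)c2c1` gives 56.3%, and compound 3 `Cc1ccc2nc(C(=O)Nc3c(F)cc(-c4cccc(F)c4)cc3F)c(C)c(C(=O)O)c2c1` gives 41.3%. On these numbers compound 3 sits between the other two: the step of a number 4 percentage points higher from compound 1 to compound 3 (within the scatter) lies within the scatter, so compound 1 and compound 3 cannot be told apart, while compound 2 stands beyond the scatter above both.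

Compound 4 `CCc1ccc2nc(C(=O)Nc3c(F)cc(-c4cccc(F)c4)cc3F)c(C)c(C(=O)O)c2c1` has not yet been measured. It differs from compound 3 in a single place: methyl in place of hydrogen on a saturated chain carbon bound to an aromatic carbon. The same change has already been made once in this set, from compound 1 to compound 2, where it produced a number 19 percentage points higher from compound 1 to compound 2 (beyond the scatter), a modest step beyond the scatter. Going by the values given here, the only other measured step, a number 4 percentage points higher from compound 1 to compound 3 (within the scatter), concerns a different group and says little about the present change. With one matching precedent, the expectation is that the step from compound 3 to compound 4 brings a rise of similar size, estimated as a number 18.7 percentage points higher from compound 3 to compound 4 (beyond the scatter). Compound 4 is therefore expected to give about 60% in this assay, with a likely range from 45% to 75%.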

Compound 4, a percentage reported as inhibition, at one concentration (the size of the read-out at that concentration, not a potency): 36.3%
Compound 4: the middle estimate sits 23.7 percentage points above what was measured; measured number outside the range, below it.
By their numbers in this assay, from the lowest: compounds 4, 1 and 3 (each within the scatter of the next); then compound 2.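

On the carboxy core, methyl to ethyl on a saturated chain carbon bound to an aromatic carbon does not repeat what it did on the hydroxy core: in this assay the step is a number 5 percentage points lower from compound 3 to compound 4 (within the scatter) and leaves the two compounds indistinguishable. The result of this small change therefore depends on which of the two groups the core carries, hydroxy or carboxy, so a step measured on one core cannot simply be carried over to the other: the same change on two cores in this assay, a number 19 percentage points higher (beyond the scatter) from compound 1 to compound 2 and a number 5 percentage points lower (within the scatter) from compound 3 to compound 4, 24 percentage points apart, beyond the scatter of two such steps. Read the other way, carboxy in place of hydroxy made no readable difference on the methyl-bearing core, yet on the ethyl-bearing core it gives a number 20 percentage points lower from compound 2 to compound 4 (beyond the scatter) and so the two changes do not simply add up: the same change on two cores in this assay, a number 4 percentage points higher (within the scatter) from compound 1 to compound 3 and a number 20 percentage points lower (beyond the scatter) from compound 2 to compound 4, 24 percentage points apart, beyond the scatter of two such steps.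

The compounds shown leave open whether a longer chain such as propyl would behave like ethyl on either core, and whether an amine or a methoxy group in place of the hydroxy would follow the hydroxy core or the carboxy core. Each number also comes from a single concentration and tells only of a stronger or weaker effect at that concentration. The data do not explain the difference between the two cores.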